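Amide variation on a nitro-substituted thiophene core

The compounds below may be only part of what the source reports. "The series", "measured", "known", "first", "only" and "open" are said of these compounds alone.

Three compounds sharing one core have been examined in a functional assay on A549 cells (Homo sapiens) for cytotoxicity, read by sulforhodamine B assay, with a stated time of 72 h; a higher number here means a weaker inhibitor, a lower number a stronger inhibitor. Compound 1, `Nc1sc(-c2ccc(Br)cc2)c(-c2ccc(Cl)cc2)c1C(=O)NC1CCCCC1`, gives 9590 nM in this assay. Compound 2, `Nc1sc(-c2ccc(Br)cc2)c(-c2ccc(Cl)cc2)c1C(=O)N1CCCC1`, carries a different amide; it differs from compound 1 by pyrrolidin-1-yl in place of cyclohexylamino on a carbonyl carbon, and the step of a 1.3-fold lower number from compound 1 to compound 2 (0.11 log units; within the scatter). Compound 3, `Nc1sc(-c2ccc([N+](=O)[O-])cc2)c(-c2ccc(Cl)cc2)c1C(=O)NC1CCCCC1`, keeps the amide of compound 1 but alters the core, differing from it by nitro in place of bromo on an aromatic carbon; the step of a 1.6-fold higher number from compound 1 to compound 3 (0.19 log units; within the scatter), and compound 3 gives 15000 nM in this assay, while compound 2 gives 7460 nM. All three numbers thus sit within the usual scatter of one another, and nothing in this small set separates them.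

Compound 4, `Nc1sc(-c2ccc([N+](=O)[O-])cc2)c(-c2ccc(Cl)cc2)c1C(=O)N1CCCC1`, has not yet been measured. It differs from compound 3 by pyrrolidin-1-yl in place of cyclohexylamino on a carbonyl carbon. This is the same change that turns compound 1 into compound 2, made at the same kind of position in both cases, on a core that differs only by the change from compound 1 to compound 3. Because the step of a 1.3-fold lower number from compound 1 to compound 2 (0.11 log units; within the scatter) lay within the scatter, the account expects the corresponding step of a 1.3-fold lower number from compound 3 to compound 4 (0.12 log units; within the scatter) to be of a similar small size. On that basis compound 4 is estimated to give 11500 nM in this assay, with a likely range from 5500 nM to 24000 nM, and the measurement will show whether this expectation holds.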

Compound 4, half-maximal inhibitory concentration: 10700 nM
The estimate for compound 4 lay 1.1-fold (0.03 log units) above the measured number; low and high end bracket the measured number.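

In this assay, pyrrolidin-1-yl in place of cyclohexylamino on a carbonyl carbon gives a 1.4-fold lower number from compound 3 to compound 4 (0.15 log units; within the scatter), and this step on the nitro-bearing core agrees with the one on the bromo-bearing core: the same change on two cores in this assay, a 1.3-fold lower number (0.11 log units; within the scatter) from compound 1 to compound 2 and a 1.4-fold lower number (0.15 log units; within the scatter) from compound 3 to compound 4, 1.1-fold (0.04 log units) apart, within the scatter of two such steps. Read along the other edge of the same four compounds, nitro in place of bromo on an aromatic carbon gives a 1.4-fold higher number from compound 2 to compound 4 (0.16 log units; within the scatter), and this step also agrees with its earlier counterpart: the same change on two cores in this assay, a 1.6-fold higher number (0.19 log units; within the scatter) from compound 1 to compound 3 and a 1.4-fold higher number (0.16 log units; within the scatter) from compound 2 to compound 4, 1.1-fold (0.04 log units) apart, within the scatter of two such steps. Both changes therefore carried from one core to the other with no gap that can be told from scatter, but every step involved is itself within the scatter, so the agreement is only among steps too small to resolve, and it does not show that a change of measurable size would carry over in the same way.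

The compounds shown leave open whether any other amide, such as morpholin-4-yl or an open-chain diethylamino group, would move the number beyond the scatter in this assay. They also leave open whether a nitrile or a methoxy group in place of the bromo or nitro would do so, and whether such a step would hold on both cores.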